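This account rests on a few compounds, and the source may have more. Where it says the series, first, only, none or still open, it means among the compounds named here.

Measured so far:
compound 1 `COc1cc(-c2cc3cc(C4C(C#N)=C(N)OC5=C4C(=O)CC(C)(C)C5)cc(C)c3oc2=O)cc(OC)c1OC` — 6.37%
compound 2 `COc1ccc(-c2cc3cc(C4C(C#N)=C(N)OC5=C4C(=O)CC(C)(C)C5)cc(C(C)(C)C)c3oc2=O)cc1` — 27.2%

Both compounds were tested in a functional assay on the whole organism (strain Swiss albino) with Mus musculus as the target, in the forced swim test, with a stated time of 5 min, at a dose of 0.5 mg/kg by the intraperitoneal route; on this read-out higher numbers stand for more inhibition at the one dose given (going by the name of the read-out) and lower numbers for less inhibition. Compound 1 gives 6.37%, while compound 2 gives 27.2%. Compound 2 therefore stands highest of the two numbers, and its nearest neighbour, compound 1, sits well below it, a gap that lies beyond the usual scatter of repeated measurements. Since compound 1 and compound 2 differ in more than one place, the two values alone show the gap; no single change is tied to it.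

Compound 3 `COc1cc(-c2cc3cc(C4C(C#N)=C(N)OC5=C4C(=O)CC(C)(C)C5)cc(C(C)(C)C)c3oc2=O)cc(OC)c1OC` has not yet been measured. It is reached from compound 2 by one change: 3,4,5-trimethoxyphenyl in place of 4-methoxyphenyl on an aromatic carbon. The shared core and its tert-butyl group stay as they are in compound 2.

Compound 1, which also carries the 3,4,5-trimethoxyphenyl group, gives only 6.37%, so the change is expected to pull the number down from compound 2, by a step of moderate size that may or may not exceed the scatter. Compound 3 is thus estimated at 15%, with a range from 3% to 30%, meaning an expected step of a number 12.2 percentage points lower from compound 2 to compound 3 (beyond the scatter).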

Compound 3, a percentage reported as inhibition, in the whole organism at one dose (the size of the read-out at that dose, not a potency): 30.1%
Estimate against measurement, compound 3: 15.1 percentage points below, and the stated range ends below it.
By their numbers in this assay, from the lowest: compound 1; then compounds 2 and 3 (each within the scatter of the next).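

In this assay, putting 3,4,5-trimethoxyphenyl in place of 4-methoxyphenyl on this aromatic carbon gives a number 2.9 percentage points higher from compound 2 to compound 3 (within the scatter), so with the tert-butyl group held constant, this read-out does not separate the two aryl groups, even though the entering group has more heavy atoms and more hydrogen-bond acceptors. The pair that shares the 3,4,5-trimethoxyphenyl group and carries tert-butyl in place of methyl on an aromatic carbon gives a number 23.7 percentage points higher from compound 1 to compound 3 (beyond the scatter), so in this one pair the low value goes with the methyl group and not with the trimethoxyphenyl group. Nothing measured here explains either result.

The compounds shown leave open whether the two aryl groups would also read alike with methyl in place of tert-butyl, as only the 3,4,5-trimethoxyphenyl group appears with methyl here. They also leave open whether the methoxy groups matter at all, which plain phenyl or 4-hydroxyphenyl at this position could test, and how an isopropyl group or a longer chain would compare with methyl and tert-butyl.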